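A Second Methyl on the Amine Nitrogen

The compounds below may be only part of what the source reports. "The series", "measured", "known", "first", "only" and "open" are said of these compounds alone.

Of the compounds shown here, three sharing one core have so far been tested in a functional assay on the whole organism for positive allosteric modulation, with Mus musculus as the target (on this read-out higher numbers stand for an effect only at larger amounts of compound and lower numbers for an effect already at smaller amounts), and none has yet given a number. Compound 1 (`Cc1cc(-c2ccccc2)nnc1NCCN`) gives > 30 mg/kg, which is a limit of the assay and not a number. Compound 2 (`Cc1cc(-c2ccccc2)nnc1NC(C)CN`) gives > 30 mg/kg, again a limit. Compound 3 (`CNCCNc1nnc(-c2ccccc2)cc1C`) gives >= 30 mg/kg, also a limit, so its place relative to the other two cannot be ranked.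

The next compound, compound 4 (`Cc1cc(-c2ccccc2)nnc1NCCN(C)C`), puts methyl in place of hydrogen on the amine nitrogen of compound 3, turning 2-(methylamino)ethyl into 2-(dimethylamino)ethyl: methyl in place of hydrogen on an amine nitrogen. The same kind of change has one precedent, a step that the two limits leave unreadable from compound 1 to compound 3, and it offers no size to carry over. The other two measured steps, a step that the two limits leave unreadable from compound 1 to compound 2 and a step that the two limits leave unreadable from compound 2 to compound 3, make different changes and are equally unreadable. With so little to go on, no clear shift in either direction is expected, and the estimated step is a number no higher from compound 3 to compound 4 (the limit leaves the size open) in this assay. Compound 4 is expected near 30 mg/kg on this estimate, with an estimated range from 12 mg/kg to 70 mg/kg and a good chance that the assay again reports only a limit.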

Compound 4, dose for half-maximal effect: > 30 mg/kg
Compound 4: a limit, no number; the forecaster's own chance of this, stated with the estimate: 65%; the middle value lies on the limit itself.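

In this assay compound 4 gives > 30 mg/kg, which is again a limit of the assay and not a number. Going by these compounds alone, all four values are limits, so no step from compound 1, compound 2 or compound 3 to compound 4 can be read. On these data alone, whether the added methyl on the amine nitrogen shifts the dose at all remains open, as does the true dose of each compound.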